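Benzylamino Analogue of Compound 1 in Cytotoxicity

The compounds below may be only part of what the source reports. "The series", "measured", "known", "first", "only" and "open" are said of these compounds alone.

Compound 1 `CNc1nc(N)nc2c1ncn2/C=C1/CC1(CO)CO` was examined in an ADME assay on MOLT-3 cells (Homo sapiens) for cytotoxicity, with a stated time of 7 days; a higher number here means that more compound is tolerated, a lower number that less compound is tolerated. There compound 1 gives > 20000 nM, which is a limit of the assay and not a number. Compound 2 `COCCOc1nc(N)nc2c1ncn2/C=C1/CC1(CO)CO` gives > 20000 nM, likewise a limit. Compound 3 `Nc1nc(OCc2ccccc2)c2ncn(/C=C3/CC3(CO)CO)c2n1` gives > 20000 nM, again a limit. Because of the limit of > 20000 nM in this assay, at which 3 of the 3 values shown sit, none of the steps among these three can be read in size: the step that the two limits leave unreadable from compound 1 to compound 2, the step that the two limits leave unreadable from compound 1 to compound 3 and the step that the two limits leave unreadable from compound 2 to compound 3 are all left unreadable by the limits. So compound 1 stands at the limit, in the same place as every other value recorded here.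

Compound 4 `Nc1nc(NCc2ccccc2)c2ncn(/C=C3/CC3(CO)CO)c2n1` has not yet been measured. It differs from compound 1 by phenyl in place of hydrogen on a saturated chain carbon bound to a nitrogen on an aromatic ring. The measured step that most resembles this change is a step that the two limits leave unreadable from compound 1 to compound 3, in which a benzyl group was also introduced, but its size cannot be read. With every measured compound sitting at the limit, no step beyond the usual scatter is expected in this assay in either direction. Compound 4 is therefore expected to give 40000 nM, within a range from 15000 nM to 100000 nM. This estimate corresponds to an expected step that the limit leaves unreadable from compound 1 to compound 4, which would most likely again be hidden behind the limit.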

Compound 4, half-maximal cytotoxic concentration: > 20000 nM
Compound 4: only a limit was reported (the forecaster's own chance of this, stated with the estimate: 85%); the middle value does not contradict the limit.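

In this assay compound 4 gives > 20000 nM, a limit and not a number. The steps from compound 4 to compound 1, compound 2 and compound 3 cannot be read in size because of this limit: the limit of > 20000 nM in this assay, at which 4 of the 4 values shown sit.

The compounds shown leave open whether the methylamino, 2-methoxyethoxy, benzyloxy and benzylamino groups differ at all in cytotoxicity.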